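This account rests on a few compounds, and the source may have more. Where it says the series, first, only, none or still open, it means among the compounds named here.

Measured so far in a functional assay on the whole organism for inhibition, with Digitaria ciliaris as the target, with a stated time of 72 h, tested at 100 mg/L; a lower number here means less inhibition of growth, a higher number more inhibition of growth at the concentration tested: compound 1 `COc1cc(C)nc2n/c(=N/C(=O)c3c(-c4ccc(Cl)cc4Cl)noc3C)sn12` gives 80.6%; compound 2 `COc1cc(Cl)nc(NC(=S)NC(=O)c2c(-c3ccc(Cl)cc3Cl)noc2C)n1` gives 62.2%; compound 3 `Cc1cc(Cl)nc(NC(=S)NC(=O)c2c(-c3ccc(Cl)cc3Cl)noc2C)n1` gives 44.2%.

Compounds 2 and 3 share a core and differ in one place: methoxy in place of methyl on an aromatic carbon. This single change made a step of a number 18 percentage points higher from compound 3 to compound 2 (beyond the scatter). Compound 1 has another core; how its core differs from that of compound 3 is not broken down here. Compound 4 `COc1cc(OC)n2s/c(=N\C(=O)c3c(-c4ccc(Cl)cc4Cl)noc3C)nc2n1` is built from compound 1 by the same kind of change: methoxy in place of methyl on an aromatic carbon. The surroundings are not the same: in compound 3 the carbon is meta to a chloro group and meta to a large group, whereas in compound 1 it sits on a ring that is part of a fused or bridged system of two rings, meta to a methoxy group, meta to a fused ring and para to a fused ring. Because the earlier step of a number 18 percentage points higher from compound 3 to compound 2 (beyond the scatter) ran upward, an upward step a number 4.4 percentage points higher from compound 1 to compound 4 (within the scatter) is expected, kept small because compound 1 already stands at 80.6%. Compound 4 is therefore estimated at 85%, between 72% and 95%.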

Compound 4, percent growth inhibition at one concentration: 85.3%
Compound 4: middle estimate off by 0.3 percentage points, on the low side, and the stated range covers the measured number.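

In this assay, putting methoxy in place of methyl on the core of compound 1 gave a step of a number 4.7 percentage points higher from compound 1 to compound 4 (within the scatter), so on this core the change has no clear effect. Set beside the earlier step, the change cannot be said to behave differently on the two cores: the same change on two cores in this assay, a number 18 percentage points higher (beyond the scatter) from compound 3 to compound 2 and a number 4.7 percentage points higher (within the scatter) from compound 1 to compound 4, 13.3 percentage points apart, within the scatter of two such steps

For the compounds shown here, this does not prove that the change carries over, since only one pair per core is available and the step on the core of compound 1 cannot be told from scatter.

The compounds shown leave open what other groups, such as an amine, an ethoxy group or a longer chain, would do at this place on the core of compound 1. They also leave open whether methoxy in place of methyl would give a clear rise on a third core.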